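Cytotoxicity notes: piperazine aryl swap in the amide series

The source may report more compounds than this note shows. Statements on the series, on what has been measured and on what is new or still open speak of the compounds shown alone.

Measured compounds:
- compound 1 `CC(=O)N1CCC(C(=O)N(CCCN2CCC(CNC(=O)c3ccsc3)CC2)c2ccc(C)c(Cl)c2)CC1` — > 51900 nM
- compound 2 `CC(=O)N1CCC(C(=O)N(CCCN2CCN(Cc3ccc(C#N)cc3)CC2)c2ccc(C)c(Cl)c2)CC1` — > 100000 nM
- compound 3 `CCN(Cc1ccccc1)C(=O)C1CCN(CCCN(C(=O)C2CCN(C(C)=O)CC2)c2ccc(C)c(Cl)c2)CC1` — 83.9 nM

In an ADME assay (Homo sapiens) for cytotoxicity (a lower number here means that less compound is tolerated, a higher number that more compound is tolerated), compound 2 gives > 100000 nM, which is a limit of the assay and not a number. Compound 1 likewise sits at a limit, > 51900 nM. Among the compounds with values here, compound 3 is the one member with a measured number, 83.9 nM. Within the data shown here, the only step within the set, an at least 610-fold lower number from compound 1 to compound 3 (2.79 log units; beyond the scatter), shows how strongly one change on the saturated ring moves the read-out.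

Compound 4 `CC(=O)N1CCC(C(=O)N(CCCN2CCN(c3ccccn3)CC2)c2ccc(C)c(Cl)c2)CC1` differs from compound 2 by pyridin-2-yl in place of 4-cyanobenzyl on an amine nitrogen in a ring. Among the measured compounds shown here, no measured step touches this position; the step from compound 1 to compound 3 concerns a different part of the shared core, so it gives no direct guidance on direction here. What bears on the expectation is that compound 2 sits at the limit of > 100000 nM in this assay, at which 1 of the 3 values shown sits, so a limit is again the most likely outcome for compound 4.

Compound 4 is therefore expected to show a step of a number no higher from compound 2 to compound 4 (the limit leaves the size open), that is none beyond the scatter, with an estimated value of 100000 nM (range 30000 nM to 300000 nM).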

Compound 4, half-maximal cytotoxic concentration: > 58300 nM
Compound 4 was reported as a limit; the forecaster's own chance of this, stated with the estimate: 70%; the middle value does not contradict the limit.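

In this assay compound 4 gives > 58300 nM, a limit of the assay and not a number. Compound 2 also sits at a limit, so the step between compound 2 and compound 4 cannot be read. The compounds shown leave open whether pyridin-2-yl or 4-cyanobenzyl on this amine nitrogen in a ring gives the lower number.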